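The compounds below may be only part of what the source reports. "The series", "measured", "known", "first", "only" and "open" are said of these compounds alone.

Three compounds set the scene. Compound 1 `COC(=O)/C=C1\Nc2cc(-c3ccccc3)ccc2OC1=O` carries a phenyl group on its fused core; compound 2 `O=C(NNC(=O)c1ccncc1)C(=O)Nc1ccc(Cl)cc1O` and compound 3 `O=C1Oc2ccccc2N/C1=C\C(=O)c1ccc(-c2ccccc2)cc1` are built differently and serve only as neighbours on the same scale. That scale is an ADME assay on Vero cells (Chlorocebus sabaeus) for cytotoxicity, read by MTT assay, with a stated time of 72 h; on this read-out higher numbers stand for lower toxicity in this test and lower numbers for higher toxicity in this test. For compound 1 the outcome in this assay is recorded as "not determined" (no result reported), so compound 1 has no number of its own to stand on. Compound 2 gives 1170000 nM in this assay. Compound 3 reaches only a limit of the test, > 366000 nM, which is not a number but the edge of what was measured. One of the three entries thus sits at that edge, as shown by the limit of > 366000 nM in this assay, at which 1 of the 3 values shown sits.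

Compound 4 `COC(=O)/C=C1\Nc2ccccc2OC1=O` is the same core as compound 1 with the phenyl group removed: hydrogen in place of phenyl on an aromatic carbon. Within the data shown here, no measured pair tracks this change, so the expected size of the step in this assay cannot be read from a comparison; the expectation is for no step beyond the scatter, in either direction. For compound 4 the estimated value in this assay is 400000 nM, with a likely range from 100000 nM to 2000000 nM.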

Compound 4, half-maximal cytotoxic concentration: > 2280000 nM
Compound 4: a limit, no number; the forecaster's own chance of this, stated with the estimate: 50%; middle value at least 5.7-fold (0.75 log units) from the limit.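

No step can be read from compound 1 to compound 4: in this assay compound 1 has the entry "not determined" (no result reported). Compound 4 gives > 2280000 nM, which is a limit and not a number. As far as these compounds go, whether hydrogen in place of phenyl on the shared core changes the result in this assay stays open.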